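Swapping Dimethylamino for Acetyl: What to Expect

The source may report more compounds than this note shows. Statements on the series, on what has been measured and on what is new or still open speak of the compounds shown alone.

Three compounds share one core and differ at a single position. In an assay on isolated protein with malate dehydrogenase, cytoplasmic (Sus scrofa) as the target (on this read-out higher numbers stand for weaker inhibition and lower numbers for stronger inhibition), compound 1 `O=C(O)c1cnc2cc(S(=O)(=O)O)ccc2c1O` gives 3090000 nM, compound 2 `CN(C)c1ccc2c(O)c(C(=O)O)cnc2c1` gives 372000 nM, and compound 3 `O=C(O)c1cnc2cc(OCCc3ccccc3)ccc2c1O` gives 155000 nM. Going by the values given here, compound 2 thus stands second highest of the three numbers, with compound 3 somewhat lower and compound 1 well higher; the only single-point step measured, an 8.3-fold lower number from compound 1 to compound 2 (0.92 log units; beyond the scatter), is a modest one. Compound 4 `CC(=O)c1ccc2c(O)c(C(=O)O)cnc2c1` changes compound 2 by acetyl in place of dimethylamino on an aromatic carbon. Among the compounds with values here, no measured step involves acetyl, so the sulfo-to-dimethylamino step shows only that this position can move the number, not how acetyl will. Compound 4 is therefore expected to give 600000 nM, between 150000 nM and 2500000 nM, an estimated 1.6-fold higher number from compound 2 to compound 4 (0.21 log units; within the scatter).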

Compound 4, half-maximal inhibitory concentration: 912000 nM
Estimate against measurement, compound 4: 1.5-fold (0.18 log units) below, and the stated range covers the measured number.
By their numbers in this assay, from the lowest: compound 3; then compound 2; then compound 4; then compound 1.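

In this assay the swap gives a 2.5-fold higher number from compound 2 to compound 4 (0.39 log units; beyond the scatter) even though both groups hold the same number of heavy atoms, so this position separates acetyl from dimethylamino, and not only sulfo from the other groups. Replacing sulfo with acetyl gives a 3.4-fold lower number from compound 1 to compound 4 (0.53 log units; beyond the scatter) and so also lowers the number, though not as far as dimethylamino does. No measurement available here explains these differences. As far as these compounds go, how a primary amine or a methyl ester would read at this position remains open, and so does whether the order seen here would hold for such groups.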